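The source may hold more compounds than are shown below. What is called first, only, known or untested is meant among the compounds shown, and "the series" means these compounds.

In a functional assay on HeLa cells (Homo sapiens) for antiproliferative activity, read by resazurin assay (on this read-out lower numbers stand for stronger inhibition and higher numbers for weaker inhibition), compound 1 `CCSC(=S)SCC(=O)c1ccc(C)cc1` gives 3980 nM, the lowest of the three numbers in hand. Compound 3 `CCSC(=S)SCC(=O)c1cc(OC)ccc1OC` gives 15800 nM in this assay, and compound 2 `Cc1ccc(C(=O)CSC(=S)SC(C)(C)C)cc1` gives 31600 nM. Within the data shown here, the only step between compounds that differ in one place, a 7.9-fold higher number from compound 1 to compound 2 (0.90 log units; beyond the scatter), concerns the group on a sulfur and not the aromatic ring, so it does not bear on the change at hand. Compound 4 `CCSC(=S)SCC(=O)c1ccc(N(CC)CC)cc1` differs from compound 1 on the aromatic ring: diethylamino in place of methyl on an aromatic carbon. Among the measured compounds shown here, no measured step addresses this kind of change; compound 1 and compound 3 show only that a different set of groups on the aromatic ring went together with a higher number, and those two differ in more than one place. In this assay the expectation is therefore a step of uncertain direction, with a higher number somewhat more likely than a lower one, and a wide range. Compound 4 is expected to give 6300 nM in this assay, between 1600 nM and 25000 nM. The expected step from the parent is a 1.6-fold higher number from compound 1 to compound 4 (0.20 log units; within the scatter).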

Compound 4, half-maximal inhibitory concentration: 3160 nM
Estimate against measurement, compound 4: 2.0-fold (0.30 log units) above, and the stated range covers the measured number.
By their numbers in this assay, from the lowest: compounds 4 and 1 (each within the scatter of the next); then compounds 3 and 2 (each within the scatter of the next).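

The step on the aromatic ring, a 1.3-fold lower number from compound 1 to compound 4 (0.10 log units; within the scatter), shows that in this assay diethylamino in place of methyl on an aromatic carbon stays within the scatter. Among these compounds, in compound 4, this position therefore carries a group of 5 heavy atoms instead of 1 with no clear shift in the number, whereas the only earlier single-place step concerned the group on a sulfur. Nothing at hand gives a reason for this result.

Open, as far as these compounds go, is whether other groups at this position, such as a carboxylic acid or the smaller dimethylamino, would also stay within the scatter of compound 1. Also open, from the compounds shown here alone, is whether diethylamino on the ring would give a similar number with tert-butyl instead of ethyl on the sulfur.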